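Ortho chloro in place of methoxy on the pendant phenyl

A few compounds are considered here, and "the series" means these few. Any claim that something is new, unique, unknown or untested is made for them only; others in the source may bear on it.

Compound 3 `COc1ccccc1-c1ccc2ncn(-c3cc(OC)c(OC)c(OC)c3)c2c1` gives 4320 nM in a functional assay on A549 cells (Homo sapiens) for antiproliferative activity, read by MTT assay, with a stated time of 72 h (a higher number here means a weaker inhibitor, a lower number a stronger inhibitor), the lowest of the two numbers shown. Compound 1 `COc1cc(-n2cnc3ccc(-c4ccc([N+](=O)[O-])cc4)cc32)cc(OC)c1OC` gives 8940 nM in this assay. Compound 2 `COc1cc(-n2cnc3ccc(-c4ccc(Cl)cc4)cc32)cc(OC)c1OC` gives > 10000 nM in this assay, which is a limit and not a number (the limit of > 10000 nM in this assay, at which 1 of the 3 values shown sits). The steps of a 2.1-fold lower number from compound 1 to compound 3 (0.32 log units; beyond the scatter) and an at least 2.3-fold lower number from compound 2 to compound 3 (0.36 log units; beyond the scatter) both favour the 2-methoxyphenyl over the para-substituted phenyls. Compound 4 `COc1cc(-n2cnc3ccc(-c4ccccc4Cl)cc32)cc(OC)c1OC` differs from compound 3 by chloro in place of methoxy on an aromatic carbon. Among the compounds with values here, no measured step alters this position alone; the closest comparison, an at least 1.1-fold higher number from compound 1 to compound 2 (0.04 log units; that floor lies within the scatter), shows that chloro in place of nitro brought no lower number. A modest rise, near the edge of the scatter, is therefore expected for a 1.4-fold higher number from compound 3 to compound 4 (0.14 log units; within the scatter). Compound 4 is estimated at 6000 nM, with a range from 2500 nM to 14000 nM.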

Compound 4, half-maximal inhibitory concentration: > 10000 nM
Compound 4: only a limit was reported; the forecaster's own chance of this, stated with the estimate: 30%; middle value at least 1.6-fold (0.22 log units) from the limit.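

In this assay, the step of an at least 2.3-fold higher number from compound 3 to compound 4 (0.36 log units; beyond the scatter) shows that the lower number of compound 3 does not survive chloro in place of methoxy on this ring, so the methoxy itself matters here, not only the ortho placement. The step of an at least 1.1-fold higher number from compound 1 to compound 4 (0.04 log units; that floor lies within the scatter) does not separate compound 4 from compound 1, and the step between compound 2 and compound 4 cannot be read. Compound 4 gives a limit and not a number: the limit of > 10000 nM in this assay, at which 2 of the 4 values shown sit.

As far as these compounds go, whether an amine, a hydroxy group or a longer chain such as ethoxy at this place would keep or lower the number stays open.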